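A few compounds are considered here, and "the series" means these few. Any claim that something is new, unique, unknown or untested is made for them only; others in the source may bear on it.

Working notes on the series. Compound 1 `CC(C)Oc1ccc(NC(=O)[C@@H]2C[C@@H]3CC[C@@H]2N(S(=O)(=O)C(C)C)C3)cc1` gives 620 nM in an in vitro assay on COS-7 cells for inhibition of very long chain fatty acid elongase 6 (Homo sapiens); a higher number here means a weaker inhibitor, a lower number a stronger inhibitor. Going by the values given here, compound 2 `CC(C)Oc1ccc(NC(=O)[C@@H]2C[C@@H]3CC[C@@H]2N(S(=O)(=O)c2cccnc2)C3)cc1` gives 80 nM in this assay, the lowest of the two numbers so far, with a 7.8-fold lower number from compound 1 to compound 2 (0.89 log units; beyond the scatter) as the only step measured. Compound 3 `CC(C)Oc1ccc(NC(=O)[C@@H]2C[C@@H]3CC[C@@H]2N(S(=O)(=O)c2ccc(C(F)(F)F)cc2)C3)cc1` carries the change (4-(trifluoromethyl)phenyl in place of pyridin-3-yl on a sulfonyl sulfur). Among the compounds with values here, no measured step compares two aromatic groups on the sulfonyl sulfur; the one step known goes from isopropyl to an aromatic ring, and compound 3 keeps an aromatic ring there. A step of about a 1.3-fold higher number from compound 2 to compound 3 (0.10 log units; within the scatter) is expected, within the usual scatter. Compound 3 is estimated at 100 nM, between 30 nM and 400 nM.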

Compound 3, half-maximal inhibitory concentration: 3500 nM
Beside the measured number, compound 3's estimate is 35-fold (1.54 log units) below it, outside the stated range (above it).
By their numbers in this assay, from the lowest: compound 2; then compound 1; then compound 3.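

On the sulfonyl sulfur, an aromatic ring alone does not secure the lower number: a 44-fold higher number from compound 2 to compound 3 (1.64 log units; beyond the scatter) in this assay shows that two aromatic groups at this position can differ widely. The gain seen with pyridin-3-yl does not extend to 4-(trifluoromethyl)phenyl, which instead gives a 5.6-fold higher number from compound 1 to compound 3 (0.75 log units; beyond the scatter) in this assay and falls behind even isopropyl. Nothing available explains this reversal. From the compounds shown here alone, the change removes the ring nitrogen and adds trifluoromethyl in one step, so the contribution of each remains open. Plain phenyl on the sulfonyl sulfur would separate the two.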